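The compounds below may be only part of what the source reports. "The series", "measured", "known", "first", "only" and "open" are said of these compounds alone.

Measured so far:
- Compound 1 `Fc1ccc(-c2[nH]c3cc(Cl)ccc3c2Cn2ccnc2)cc1`: in an assay on isolated protein for inhibition of Aromatase (Homo sapiens), read by ELISA, using NADPH, with a stated time of 24 h (on this read-out lower numbers stand for stronger inhibition and higher numbers for weaker inhibition), compound 1 gives 32.3 nM.
- Compound 2 `COc1ccc(-c2[nH]c3cc(F)ccc3c2Cn2ccnc2)cc1`: in this assay compound 2 gives 36.1 nM.

Compound 2 holds the higher of the two numbers, yet the gap to compound 1 lies within the scatter of repeated measurements, so the two cannot be told apart. Compound 1 and compound 2 differ in two places, and their values show only that both sit close together.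

Compound 3 `COc1ccc(-c2[nH]c3cc(Cl)ccc3c2Cn2ccnc2)cc1` is not yet measured. It arises from compound 2 by one change: chloro in place of fluoro on an aromatic carbon. Compound 1 already carries chloro at this place, alongside fluoro on its pendant ring, and gives a number close to compound 2. Among the measured compounds shown here, no measured pair isolates this change, so the expected step in this assay is small, with no direction beyond the scatter; the estimated step is a 1.2-fold lower number from compound 2 to compound 3 (0.08 log units; within the scatter). Compound 3 is therefore expected to give about 30 nM, in a range from 12 nM to 75 nM.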

Compound 3, half-maximal inhibitory concentration: 277 nM
Estimate against measurement, compound 3: 9.2-fold (0.97 log units) below, outside the stated range (above it).
By their numbers in this assay, from the lowest: compounds 1 and 2 (each within the scatter of the next); then compound 3.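

In this assay, chloro in place of fluoro on this aromatic carbon proves to be far from a neutral exchange, giving a 7.7-fold higher number from compound 2 to compound 3 (0.88 log units; beyond the scatter), although each group counts only one heavy atom. With chloro held fixed, methoxy in place of fluoro at the other changed place gives an 8.6-fold higher number from compound 1 to compound 3 (0.93 log units; beyond the scatter), so chloro at this position does not by itself go with the higher number, and the step seen alongside methoxy need not hold alongside another group. Nothing shown accounts for the size of either step.

The compounds shown leave open whether the step from fluoro to chloro recurs when methoxy is replaced by another group. They also leave open how a bromo group or an amine would behave on this aromatic carbon.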